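The compounds below may be only part of what the source reports. "The series", "measured", "known", "first", "only" and "open" are said of these compounds alone.

Working notes on the series. In a functional assay on BJAB cells (Homo sapiens) for antiproliferative activity, with a stated time of 4 days (on this read-out lower numbers stand for an effect already at smaller amounts and higher numbers for an effect only at larger amounts of compound), compound 1 `Cc1cc(C#N)cc(-c2c(C)nn(-c3nc(-c4ccc(Cl)c(Cl)c4)c(SC(C)C)s3)c2C(=O)O)c1` gives 4800 nM, the second highest of three numbers. Compound 2 `Cc1nn(-c2nc(-c3ccc(Cl)c(Cl)c3)c(SC(C)C)s2)c(C(=O)O)c1-c1cc(C(F)(F)F)cc(C(F)(F)F)c1` gives 1800 nM in this assay, a lower number than compound 1 by more than the scatter. Compound 3 `COC(=O)c1c(Cc2ccccc2[N+](=O)[O-])c(C)nn1-c1nc(-c2ccc(Cl)c(Cl)c2)c(SC(C)C)s1`, the only ester in the set, gives 93000 nM in this assay, far above compound 1.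

Compound 4 `Cc1nn(-c2nc(-c3ccc(Cl)c(Cl)c3)c(SC(C)C)s2)c(C(=O)O)c1-c1ccc(C(F)(F)F)cc1` is not yet measured. It differs from compound 1 in one place: 4-(trifluoromethyl)phenyl in place of 3-cyano-5-methylphenyl on an aromatic carbon. Among the compounds with values here, no measured pair isolates this change. Given that compound 2, which carries two trifluoromethyl groups on the same phenyl, gives 1800 nM, the step from compound 1 to compound 4 in this assay is expected to be small and downward, a 1.6-fold lower number from compound 1 to compound 4 (0.20 log units; within the scatter), possibly within the scatter. The estimate for compound 4 in this assay is 3000 nM, in a range of 1200 nM to 8000 nM.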

Compound 4, half-maximal effective concentration: 3500 nM
For compound 4 the middle estimate is 1.2-fold (0.07 log units) below the measured one, within the range that was stated.
By their numbers in this assay, from the lowest: compounds 2, 4 and 1 (each within the scatter of the next, the first and the last beyond it); then compound 3.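

In this assay, within the data shown here, the exchange of 3-cyano-5-methylphenyl for 4-(trifluoromethyl)phenyl on this aromatic carbon gives a 1.4-fold lower number from compound 1 to compound 4 (0.14 log units; within the scatter) and is the first one-place comparison at this position. The step shows that the nitrile and the methyl of compound 1 can both leave together with no change beyond the scatter, provided a 4-(trifluoromethyl)phenyl takes their place. Nothing at hand gives a reason for this result.

The compounds shown leave open how an unsubstituted phenyl, a phenyl bearing an amine, or a longer alkyl chain in place of the aryl group would read at this position.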